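The source may report more compounds than this note shows. Statements on the series, on what has been measured and on what is new or still open speak of the compounds shown alone.

Compound 3 `COc1ccc(-c2ncnn2-c2cc(OC)c(OC)c(OC)c2)cc1` carries the lowest of the two numbers obtained in a functional assay on Jurkat cells (Homo sapiens) for antiproliferative activity, read by MTT assay, with a stated time of 72 h (a lower number here means a stronger inhibitor, a higher number a weaker inhibitor), giving 50 nM. For the measured compounds named here, compound 1 `COc1cc(-n2ncnc2-c2ccc(C)cc2)cc(OC)c1OC` gives 300 nM in this assay, and the step of a 6.0-fold lower number from compound 1 to compound 3 (0.78 log units; beyond the scatter) is the only single-change step measured in the set. Compound 2 `COc1cc(-c2ncnn2-c2ccc(Cl)cc2Cl)cc(OC)c1OC` reaches only the limit > 10000 nM in this assay (the limit of > 10000 nM in this assay, at which 1 of the 3 values shown sits). Compound 4 `COc1cc(-n2ncnc2-c2ccc(Cl)cc2)cc(OC)c1OC` differs from compound 3 by chloro in place of methoxy on an aromatic carbon. Going by the values given here, no measured step covers chloro in place of methoxy; the one step known exchanges methyl for methoxy on an aromatic carbon, and chloro is expected to land nearer the methyl case than the methoxy case, so a higher number is anticipated. The expected step is a 6.0-fold higher number from compound 3 to compound 4 (0.78 log units; beyond the scatter). Compound 4 is therefore estimated at 300 nM, within 80 nM to 1200 nM.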

Compound 4, half-maximal inhibitory concentration: > 10000 nM
Compound 4: only a limit was reported; the forecaster's own chance of this, stated with the estimate: 5%; middle value at least 33-fold (1.52 log units) away from the limit.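

In this assay chloro in place of methoxy gives an at least 200-fold higher number from compound 3 to compound 4 (2.30 log units; beyond the scatter) and chloro in place of methyl gives an at least 33-fold higher number from compound 1 to compound 4 (1.52 log units; beyond the scatter) so the site para to a large group separates these groups far more sharply than the methyl to methoxy step alone suggested. Compound 4 gives a limit, not a number, so the true size of both steps stays unfixed: the limit of > 10000 nM in this assay, at which 2 of the 4 values shown sit. The compounds shown leave open how an amine, a hydroxyl or an ethoxy group would read at this site, so the range of groups it accepts remains unsettled.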